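Changing the amine on compound 3

The source may hold more compounds than are shown below. What is called first, only, known or untested is meant among the compounds shown, and "the series" means these compounds.

Measured in a functional assay on NCI-H460 cells (Homo sapiens) for inhibition, read by sulforhodamine B assay, with a stated time of 72 h; a higher number here means a weaker inhibitor, a lower number a stronger inhibitor:
compound 1 `CC(C)c1cc(-n2cc(-c3ccc(CN4CCN(c5ccccc5)CC4)cc3)nn2)c(O)cc1O`: > 1000 nM (a limit)
compound 2 `CC(C)c1cc(-n2cc(-c3ccc(CN4CCN(Cc5ccccc5)CC4)cc3)nn2)c(O)cc1O`: > 1000 nM (a limit)
compound 3 `CCNC(=O)c1nnn(-c2cc(C(C)C)c(O)cc2O)c1-c1ccc(CN2CCC[C@H](O)C2)cc1`: 70 nM

In this assay, going by the values given here, compound 3 gives 70 nM, the only true number in this small set. The rest of the set stands at the limit of > 1000 nM in this assay, at which 2 of the 3 values shown sit.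

Compound 4 `CCNC(=O)c1nnn(-c2cc(C(C)C)c(O)cc2O)c1-c1ccc(CN(CC)CC)cc1`, not yet measured, differs from compound 3 in one place: diethylamino in place of 3-hydroxypiperidin-1-yl on a saturated chain carbon bound to an aromatic carbon.

Among the compounds with values here, no measured step covers this change. Within the data shown here, the only step available is a step that the two limits leave unreadable from compound 1 to compound 2. It is a different change, benzyl in place of phenyl on an amine nitrogen in a ring, and it offers no readable size to carry over. Among the measured compounds shown here, with no measured step to set a size or a direction, no step beyond the scatter is expected, and the expectation stays anchored on compound 3 at 70 nM, with a wide range.

The estimate amounts to an expected 1.1-fold higher number from compound 3 to compound 4 (0.06 log units; within the scatter). For compound 4 the estimated value is 80 nM, with an expected range of 25 nM to 250 nM.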

Compound 4, half-maximal inhibitory concentration: 11 nM
The estimate for compound 4 lay 7.3-fold (0.86 log units) above the measured number, outside the stated range (below it).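

In this assay, replacing 3-hydroxypiperidin-1-yl with diethylamino on the saturated chain carbon gives a 6.4-fold lower number from compound 3 to compound 4 (0.80 log units; beyond the scatter) and thus a step beyond the scatter. Going by these compounds alone, the only earlier step, which also concerned the amine, cannot be read, so this is the first readable size for a change of amine in the set, and it shows that this position tolerates losing the ring, the hydroxyl and the defined stereocentre in one change. Nothing in the data shown accounts for the size of this step.

Those features all change together, so the compounds shown do not separate their contributions. Piperidin-1-yl without the hydroxyl would separate the hydroxyl from the ring, while dimethylamino or a longer chain such as dipropylamino would show how far the open-chain amine can vary.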